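The source may report more compounds than this note shows. Statements on the series, on what has been measured and on what is new or still open speak of the compounds shown alone.

Compound 1, `O=C1CSC(c2ccc([N+](=O)[O-])cc2)N1CCN1CCCCC1`, was examined in an ADME assay on Vero cells (Chlorocebus sabaeus) for cytotoxicity, read by neutral red uptake, tested at 49 ug/mL (a higher number here means a weaker effect of the compound at the concentration tested, a lower number a stronger effect), and gives 100%. Compound 2, `COc1cccc(C2SCC(=O)N2CCN2CCCCC2)c1`, gives 90% in this assay, a number lying within the usual scatter of the result of compound 1, so the two cannot be told apart on these figures. Going by the values given here, no pair of measured compounds differing in a single place is available for comparison. Compound 3, `O=C1CSC(c2ccc(Cl)cc2)N1CCN1CCCCC1`, departs from compound 1 in one place: chloro in place of nitro on an aromatic carbon. No step beyond the scatter is expected in this assay in either direction, the expected shift being a number 5 percentage points lower from compound 1 to compound 3 (within the scatter). Compound 3 is accordingly expected to give 95% in this assay, with a range from 75% to 105%.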

Compound 3, a percentage reported as activity, at one concentration (the size of the read-out at that concentration, not a potency): 84%
Estimate against measurement, compound 3: 11 percentage points above; the range from low to high includes it.
By their numbers in this assay, from the lowest: compounds 3, 2 and 1 (each within the scatter of the next, the first and the last beyond it).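

Going by these compounds alone, compound 3 gives the first single-place comparison in this assay, and the swap of nitro for chloro on this aromatic carbon, para to a large group, gives a number 16 percentage points lower from compound 1 to compound 3 (beyond the scatter), which is a shift toward a stronger effect at the concentration tested. This position therefore responds to the change, though only modestly, and nothing available accounts for the step. On these data alone, whether an amine or a carboxylic acid on the same carbon would shift the read-out further remains open, as does whether chloro elsewhere on the ring would give a similar step.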